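The compounds below may be only part of what the source reports. "The series", "measured", "known", "first", "only" and "open" are said of these compounds alone.

Series measured in an ADME assay for permeability, using PAMPA; a lower number here means that the compound crosses the layer more slowly, a higher number that the compound crosses the layer faster:
- compound 1 `O=C(Nc1ccc([N+](=O)[O-])cc1Cl)c1cc(F)ccc1O`: "not determined" (no result reported)
- compound 2 `COc1ccc(O)c(C(=O)Nc2ccc([N+](=O)[O-])cc2Cl)c1`: 67.1 10^-6 cm/s
- compound 3 `CC(=O)c1ccc(O)c(C(=O)Nc2ccc([N+](=O)[O-])cc2Cl)c1`: 33.1 10^-6 cm/s

Compound 3, at 33.1 10^-6 cm/s, holds the lower of the two numbers in this assay, and compound 1 offers no number for comparison. Compound 4 `O=C(Nc1ccc([N+](=O)[O-])cc1Cl)c1cc(-c2ccc(F)cc2F)ccc1O` carries 2,4-difluorophenyl in place of acetyl on an aromatic carbon. Within the data shown here, only one measured step bears on this change: a 2.0-fold lower number from compound 2 to compound 3 (0.31 log units; beyond the scatter), a modest drop with acetyl in place of methoxy on an aromatic carbon. Among the measured compounds shown here, no measured compound carries the entering group, so the direction is tentative. With acetyl leaving, a step upward of about that size is expected: a 2.0-fold higher number from compound 3 to compound 4 (0.29 log units; within the scatter). For compound 4 the estimate is 65 10^-6 cm/s, with an expected range of 20 10^-6 cm/s to 160 10^-6 cm/s.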

Compound 4, apparent permeability: < 23.7 10^-6 cm/s
Compound 4: no number, only a limit (the forecaster's own chance of this, stated with the estimate: 5%); middle value at least 2.7-fold (0.43 log units) away from the limit.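

Para to the hydroxy group, 2,4-difluorophenyl gives compound 4 a limit rather than a number in this assay: the limit of < 23.7 10^-6 cm/s in this assay, at which 1 of the 4 values shown sits. Replacing methoxy with this ring gives a clear drop, an at least 2.8-fold lower number from compound 2 to compound 4 (0.45 log units; beyond the scatter). Replacing acetyl gives an at least 1.3-fold lower number from compound 3 to compound 4 (0.14 log units; that floor lies within the scatter), so that floor alone does not separate the two compounds.

On these data alone, how far the true value of compound 4 lies past its limit remains open. Also open, as far as these compounds go, is whether an amine or a carboxylic acid on this carbon would give a number on the scale.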